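This account rests on a few compounds, and the source may have more. Where it says the series, first, only, none or still open, it means among the compounds named here.

In an in vitro ADME assay on microsomes from liver (Homo sapiens) for metabolic stability, tested at 1 uM (on this read-out lower numbers stand for a shorter-lived compound and higher numbers for a longer-lived compound), compound 1 (`CN(C)c1ccc(C(=O)N2CCC(NS(=O)(=O)c3cc(S(=O)(=O)c4ccccc4)ccc3C(F)(F)F)CC2)cn1`) gives 0.05 h as its half-life. Compound 2 (`O=C(O)c1cccc(S(=O)(=O)N2CCC(NS(=O)(=O)c3cc(S(=O)(=O)c4ccccc4)ccc3C(F)(F)F)CC2)c1`) reads > 0.5 h in this assay and this is a limit of the assay, not a number. Among the measured compounds shown here, the one measured step (an at least 10-fold higher number from compound 1 to compound 2 (1.00 log units; beyond the scatter)) brought in (3-carboxyphenyl)sulfonyl in place of (6-(dimethylamino)pyridin-3-yl)carbonyl on an amine nitrogen in a ring, and its full size stays open. Compound 3 (`CC(C)(O)CCN1CCC(NS(=O)(=O)c2cc(S(=O)(=O)c3ccccc3)ccc2C(F)(F)F)CC1`) changes that same nitrogen, with 3-hydroxy-3-methylbutyl in place of (3-carboxyphenyl)sulfonyl (3-hydroxy-3-methylbutyl in place of (3-carboxyphenyl)sulfonyl on an amine nitrogen in a ring). For the measured compounds named here, the group that leaves is the one gained in the only measured step (an at least 10-fold higher number from compound 1 to compound 2 (1.00 log units; beyond the scatter)), so part of that rise is expected to be lost, although compound 3 carries neither group of that step. A step down is therefore expected (an at least 2.0-fold lower number from compound 2 to compound 3 (0.30 log units; that floor lies within the scatter)). The estimated half-life for compound 3 is 0.25 h (0.08 h to 0.7 h).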

Compound 3, half-life: < 0.0167 h
Compound 3 was reported as a limit; the forecaster's own chance of this, stated with the estimate: 25%; at least 14-fold (1.17 log units) between middle value and limit.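

Replacing (3-carboxyphenyl)sulfonyl with 3-hydroxy-3-methylbutyl on this ring nitrogen gives an at least 29-fold lower number from compound 2 to compound 3 (1.47 log units; beyond the scatter), so the earlier rise is more than undone. The same chain also compares poorly with (6-(dimethylamino)pyridin-3-yl)carbonyl, giving an at least 2.9-fold lower number from compound 1 to compound 3 (0.47 log units; beyond the scatter), which shows that a change at this nitrogen can shorten the half-life as well as lengthen it. Compound 3 reads as a limit of the assay, not a number, so the full size of both steps stays open: the limit of < 0.0167 h in this assay, at which 1 of the 3 values shown sits.

The compounds shown do not separate the part played by the carboxylic acid from that of the sulfonyl link, which a plain phenylsulfonyl group or a benzoyl group bearing a carboxylic acid could do. They also leave open whether the hydroxyl of the chain matters, as a simple alkyl chain would show.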